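Cytotoxicity on macrophage cells: dimethylamino in place of nitro

The source may report more compounds than this note shows. Statements on the series, on what has been measured and on what is new or still open speak of the compounds shown alone.

Measured compounds:
compound 1 `Cc1c(C(=O)N/N=C/c2ccc([N+](=O)[O-])cc2)no[n+]1[O-]` — > 300000 nM
compound 2 `O=C(N/N=C/c1ccc2nonc2c1)c1cccnc1` — 209000 nM
compound 3 `Cc1c(C(=O)N/N=C/c2cccs2)ns[n+]1[O-]` — > 400000 nM

In an ADME assay on J774.1 cells (Mus musculus) for cytotoxicity, read by MTT assay, with a stated time of 48 h (on this read-out lower numbers stand for stronger inhibition and higher numbers for weaker inhibition), compound 1 gives > 300000 nM, which is a limit of the assay and not a number. Compound 2 gives 209000 nM in this assay. Compound 3 gives > 400000 nM in this assay, again a limit of the assay. Within the data shown here, compound 1 therefore stands at one of the two limits among the three values, (the limit of > 300000 nM in this assay, at which 1 of the 3 values shown sits), while the other limit is the limit of > 400000 nM in this assay, at which 1 of the 3 values shown sits; none of the three compounds shows marked toxicity toward these cells, and no two measured compounds differ in only one place, so no measured step tells how a single change moves the read-out in this assay.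

Compound 4 `Cc1c(C(=O)N/N=C/c2ccc(N(C)C)cc2)no[n+]1[O-]` is the next compound to be measured. Compared with compound 1 it carries dimethylamino in place of nitro on an aromatic carbon. Among the measured compounds shown here, the three values so far give no ground for expecting a change beyond the scatter from this kind of substitution, so the step of a number no higher from compound 1 to compound 4 (the limit leaves the size open) is expected to be small or none beyond the scatter. Compound 4 is accordingly estimated at 300000 nM in this assay, within a range from 100000 nM to 1000000 nM, with a fair chance that only a limit is reported.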

Compound 4, half-maximal inhibitory concentration: 129000 nM
Beside the measured number, compound 4's estimate is 2.3-fold (0.37 log units) above it; the measured number falls inside the stated range.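

In this assay, dimethylamino in place of nitro on an aromatic carbon of a six-membered aromatic ring of carbon only, para to a large group, gives an at least 2.3-fold lower number from compound 1 to compound 4 (0.36 log units; beyond the scatter), the only single-place step among the compounds shown. The read-out therefore responds to the group at this position, a point that compound 2 and compound 3 could not address, and compound 4 gives a measured number of 129000 nM. Compound 1 stands at a limit of the assay and not at a number, so the step has a lower bound but no known full size: the limit of > 300000 nM in this assay, at which 1 of the 4 values shown sits.

Only nitro and dimethylamino are shown at this position, so it remains open whether the step tracks the group that leaves or the group that enters, and a primary amine, a methoxy group or plain hydrogen on the same carbon would help separate the two. From the compounds shown here alone, compound 2 and compound 3 differ from compound 1 and compound 4 in more than one place, so whether the same exchange would move the read-out on their cores also remains open.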